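Amine swap on the acrylamide chain: pyrrolidine to hydroxymethylpiperidine

The compounds below may be only part of what the source reports. "The series", "measured", "known", "first", "only" and "open" are said of these compounds alone.

Measured compounds in a functional assay on PC-3 cells (Homo sapiens) for antiproliferative activity, read by MTT assay, with a stated time of 72 h; on this read-out lower numbers stand for stronger inhibition and higher numbers for weaker inhibition:
- compound 1, `CCC/C=C/C(=O)Nc1cc2c(N3CCc4ccccc43)ncnc2cc1O[C@@H]1CCOC1`: 9230 nM
- compound 2, `O=C(/C=C/CN1CCCC1)Nc1cc2c(N3CCc4ccccc43)ncnc2cc1O[C@@H]1CCOC1`: 1510 nM

Among the measured compounds shown here, compound 2 holds the lower of the two numbers so far; its nearest neighbour, compound 1, differs only by ethyl in place of pyrrolidin-1-yl on the saturated chain carbon bound to the double-bonded chain carbon, and the step of a 6.1-fold lower number from compound 1 to compound 2 (0.79 log units; beyond the scatter) lies beyond the scatter. For the measured compounds named here, that is the only measured step, and it concerns the same position as the next change.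

Compound 3, `O=C(/C=C/CN1CCC(CO)CC1)Nc1cc2c(N3CCc4ccccc43)ncnc2cc1O[C@@H]1CCOC1`, is not yet measured. Its difference from compound 2 is 4-(hydroxymethyl)piperidin-1-yl in place of pyrrolidin-1-yl on a saturated chain carbon bound to a double-bonded chain carbon. Going by the values given here, the basic nitrogen on the chain is kept, so the step from compound 1 to compound 2 does not bear on it directly; there is no measured pair in which one cyclic amine replaces another at this position. With the amine retained, the expectation is a step from compound 2 to compound 3 of a 1.0-fold lower number from compound 2 to compound 3 (0.00 log units; within the scatter), that is, no change beyond the scatter. Compound 3 is therefore expected to give about 1500 nM in this assay, within a range of 600 nM to 4000 nM.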

Compound 3, half-maximal inhibitory concentration: 3310 nM
Beside the measured number, compound 3's estimate is 2.2-fold (0.34 log units) below it; the measured number falls inside the stated range.
By their numbers in this assay, from the lowest: compound 2; then compound 3; then compound 1.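

In this assay, this position does not treat the two cyclic amines as interchangeable: 4-(hydroxymethyl)piperidin-1-yl in place of pyrrolidin-1-yl on the saturated chain carbon gives a 2.2-fold higher number from compound 2 to compound 3 (0.34 log units; beyond the scatter), so the gain seen earlier over ethyl depends on which amine is present and not only on an amine being there. The same group in place of ethyl still gives a 2.8-fold lower number from compound 1 to compound 3 (0.45 log units; beyond the scatter), which places both amine-bearing compounds on the lower side of the ethyl compound, a pattern that rests on these two amines alone. No supporting data bear on why the number moves with this swap.

The change alters ring size and adds hydroxymethyl in one step, so the compounds shown do not separate these two contributions; unsubstituted piperidin-1-yl, or pyrrolidin-1-yl carrying a hydroxymethyl group, would divide the step into its parts. As far as these compounds go, whether an acyclic amine such as dimethylamino, or a ring with a second hetero atom such as morpholin-4-yl, follows the same trend at this position also remains open.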